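Swapping a pyridine for a sulfonyl-bearing phenyl on the amide

A few compounds are considered here, and "the series" means these few. Any claim that something is new, unique, unknown or untested is made for them only; others in the source may bear on it.

Measured so far:
compound 1, `COc1ccc(Cl)cc1C[C@@H]1CN/C(=N\N(C)C)CN(CC(=O)Nc2ccccn2)C1=O`: 16000 nM
compound 2, `COc1ccc(Cl)cc1C[C@@H]1CN/C(=N\O)CN(CC(=O)Nc2cccc(C(=O)O)c2)C1=O`: > 30000 nM

Of the compounds shown here, two sharing one core have been tested in an assay on isolated protein for inhibition of kallikrein-7 (Homo sapiens), read by fluorescence, with stated times of 10 min and 30 min; a lower number here means a stronger inhibitor, a higher number a weaker inhibitor. Compound 1 gives 16000 nM in this assay, a weak result, and it is the only actual number shown. Compound 2 reaches only (the limit of > 30000 nM in this assay, at which 1 of the 2 values shown sits), which is a limit of the assay and not a number. For the measured compounds named here, compound 2 differs from compound 1 in more than one place, so no single step between them can be read.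

Compound 3, `COc1ccc(Cl)cc1C[C@@H]1CN/C(=N\N(C)C)CN(CC(=O)Nc2cccc(S(C)(=O)=O)c2)C1=O`, is not yet measured. It differs from compound 1 in one place: 3-(methylsulfonyl)phenyl in place of pyridin-2-yl on an amide-type nitrogen.

Going by the values given here, with no measured step to lean on, the size of the expected change can only be guessed loosely. The change is expected to be small, at most a modest gain in this assay, and quite possibly none beyond the scatter, so compound 3 is expected to give 10000 nM, within a range from 3000 nM to 30000 nM. This estimate means an expected step of a 1.6-fold lower number from compound 1 to compound 3 (0.20 log units; within the scatter) in this assay.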

Compound 3, half-maximal inhibitory concentration: 820 nM
The estimate for compound 3 lay 12-fold (1.09 log units) above the measured number; measured number outside the range, below it.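

In this assay, the group on the amide-type nitrogen proves to matter a great deal: 3-(methylsulfonyl)phenyl in place of pyridin-2-yl gives a 20-fold lower number from compound 1 to compound 3 (1.29 log units; beyond the scatter). For the compounds shown here, this is the first step that can be read as a single change. Everything else in compound 1 stays the same in compound 3, and the whole difference belongs to this one swap. No measurement shown bears on what lies behind the gain, so it can be tied only to the swap as a whole and not to any one part of it.

The swap changes two things at once, replacing the ring nitrogen with an all-carbon ring and adding the methylsulfonyl group, and the compounds shown do not separate the two, which a plain phenyl on the same nitrogen would begin to do. Going by these compounds, it also remains open whether the methylsulfonyl group itself is needed, or whether a sulfonamide, a nitrile or an amine in its place on the phenyl ring would hold the same level of inhibition.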